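The source may hold more compounds than are shown below. What is called first, only, known or untested is meant among the compounds shown, and "the series" means these compounds.

Compound 1 `Cc1ccc(Cn2c(/C=C3\SC(=S)N(CC(=O)O)C3=O)nc3cc(F)ccc32)cc1` and compound 2 `COc1ccc2c(c1)nc(/C=C1\SC(=S)N(CC(=O)O)C1=O)n2Cc1ccc(C)cc1` share one core and differ at a single aromatic carbon: methoxy in place of fluoro on an aromatic carbon. In a functional assay on A549 cells (Homo sapiens) for cytotoxicity, read by MTT assay, with a stated time of 48 h (a lower number here means a stronger inhibitor, a higher number a weaker inhibitor), compound 1 gives 13800 nM, and in this assay compound 2 gives 5680 nM; the step is a 2.4-fold lower number from compound 1 to compound 2 (0.39 log units; beyond the scatter). Compound 3 `O=C(O)CN1C(=O)/C(=C/c2nc3ccc(F)cc3n2Cc2ccccc2F)SC1=S` carries a different substituent on the benzyl part, and the difference between its core and that of compound 1 is not broken down here. In this assay compound 3 gives only a limit, > 50000 nM, the reading sitting at the limit of > 50000 nM in this assay, at which 1 of the 3 values shown sits. Compound 4 `COc1ccc2nc(/C=C3\SC(=S)N(CC(=O)O)C3=O)n(Cc3ccccc3F)c2c1` is to be measured in this assay and stands to compound 3 as compound 2 stands to compound 1: methoxy in place of fluoro on an aromatic carbon, the same change at the same place. Among the compounds with values here, the one measured instance of this change is a 2.4-fold lower number from compound 1 to compound 2 (0.39 log units; beyond the scatter). On that basis a step of similar, modest size is expected for compound 4, an at least 1.6-fold lower number from compound 3 to compound 4 (0.22 log units; that floor lies within the scatter). The starting point for compound 3 is a limit rather than a number, and compound 4 may itself return only a limit. Compound 4 is estimated at 30000 nM, between 9000 nM and 80000 nM.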

Compound 4, half-maximal inhibitory concentration: 36200 nM
Estimate against measurement, compound 4: 1.2-fold (0.08 log units) below, within the range that was stated.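

In this assay, methoxy in place of fluoro on an aromatic carbon on the core of compound 3 gives an at least 1.3-fold lower number from compound 3 to compound 4 (0.14 log units; that floor lies within the scatter), so the lower number seen on the core of compound 1 is not contradicted, although this floor alone does not establish a step beyond the scatter. The two cores can be set side by side only loosely, and the data do not show that the step carries over at the same size: the same change on two cores in this assay, a 2.4-fold lower number (0.39 log units; beyond the scatter) from compound 1 to compound 2 and an at least 1.3-fold lower number (0.14 log units; that floor lies within the scatter) from compound 3 to compound 4; the limit leaves it open whether they differ. On these data alone, the reading for compound 3 is a limit and not a number, so the true size of the second step remains unknown: the limit of > 50000 nM in this assay, at which 1 of the 4 values shown sits.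

Open, as far as these compounds go, is whether a lower number would also follow with an amine, a chloro group or a longer alkoxy chain such as ethoxy on the same aromatic carbon. Also open, from the compounds shown here alone, is how the benzyl substituent alone bears on the reading, as the cores of compound 1 and compound 3 are not compared here through a single-place step.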